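The source may report more compounds than this note shows. Statements on the series, on what has been measured and on what is new or still open speak of the compounds shown alone.

Compound 1 `C#CCNC1CCc2c(OCc3cccc(C(F)(F)F)c3)cccc21` gives 6410 nM in an assay on isolated protein for inhibition of Amine oxidase [flavin-containing] B (Homo sapiens); on this read-out higher numbers stand for weaker inhibition and lower numbers for stronger inhibition.
Compound 2 `C#CCNC1CCc2c(SCc3ccc(Br)cc3)cccc21` gives 1310 nM in this assay.
Compound 3 `C#CCNC1CCc2c(SCCc3ccc(C)cc3)cccc21` gives 25800 nM in this assay.

Among these three, compound 3 has the highest number and is therefore the weakest inhibitor of the set. Its nearest neighbour is compound 1, which shows a lower number, and compound 2 lies further away with a lower number still; both gaps are beyond the usual scatter of this kind of measurement.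

Compound 4 `C#CCNC1CCc2c(SCCc3cccc(Br)c3)cccc21` has not yet been measured. It differs from compound 3 in one place: 3-bromophenyl in place of 4-methylphenyl on a saturated chain carbon, two bonds along the chain from a sulfur. Within the data shown here, no pair among the measured compounds differs in just this way, so the size of this step cannot be read off directly. Compound 2, which also carries a bromine on its ring, shows the lowest number of the three, while compound 3 with its methyl shows the highest; these two compounds also differ in the length of the chain between the sulfur and the ring, so the comparison does not isolate the bromine alone.

A modest step toward stronger inhibition is expected from compound 3 to compound 4, a 2.6-fold lower number from compound 3 to compound 4 (0.41 log units; beyond the scatter). Compound 4 is accordingly estimated at 10000 nM, with a range from 2500 nM to 40000 nM.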

Compound 4, half-maximal inhibitory concentration: 30500 nM
Beside the measured number, compound 4's estimate is 3.1-fold (0.48 log units) below it, and the stated range covers the measured number.
By their numbers in this assay, from the lowest: compound 2; then compound 1; then compounds 3 and 4 (each within the scatter of the next).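

In this assay, placing 3-bromophenyl in place of 4-methylphenyl on a saturated chain carbon, two bonds along the chain from a sulfur, gives a 1.2-fold higher number from compound 3 to compound 4 (0.07 log units; within the scatter), so at this position the two groups cannot be told apart on this read-out, even though the swap alters both the atom on the ring and where it sits. Among these compounds, this is the first direct comparison in the set. Compounds 1 and 2 each differ from compound 3 and compound 4 in more than one place. The comparison shows that, on this chain and with these two rings, a bromine does not by itself set a compound apart from one carrying a methyl. No measurement shown here explains why the two groups read alike.

From the compounds shown here alone, what remains open is how each part of the swap acts alone, which 4-bromophenyl or 3-methylphenyl on the same chain would separate. Going by these compounds, it is also open whether this position responds at all to a different kind of group, such as an amine or a carboxylic acid on the ring, or to a longer chain between the sulfur and the ring.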